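The source may report more compounds than this note shows. Statements on the series, on what has been measured and on what is new or still open speak of the compounds shown alone.

Measured in a functional assay on HeLa cells (Homo sapiens) for antiproliferative activity, read by MTT assay, with a stated time of 72 h; a lower number here means a stronger inhibitor, a higher number a weaker inhibitor:
Compound 1 `COc1cc(C(=O)c2sc3ccccc3c2-c2ccc(Cl)cc2)cc(OC)c1OC`: 5200 nM
Compound 2 `COc1ccc(-c2c(C(=O)c3cc(OC)c(OC)c(OC)c3)sc3ccccc23)cc1C`: 10000 nM

Compound 2 stands within the usual scatter of compound 1, so these two values describe one level of activity and not a ranking. The next compound, compound 3 `CCOc1ccc(Nc2c(C(=O)c3cc(OC)c(OC)c(OC)c3)sc3ccccc23)cc1`, keeps the shared core and alters the same place: (4-ethoxyphenyl)amino in place of 4-methoxy-3-methylphenyl on an aromatic carbon. In words, (4-ethoxyphenyl)amino takes the place of 4-methoxy-3-methylphenyl on an aromatic carbon.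

Among the compounds with values here, only one measured step bears on this change: a 1.9-fold higher number from compound 1 to compound 2 (0.28 log units; within the scatter). It lies within the scatter, and it shows that one swap at this place left this assay without a clear shift. Within the data shown here, neither measured compound carries an amino group, however, so the new group has no direct precedent here. A modest move towards a lower number is therefore only a cautious expectation, and a larger move in either direction remains possible. The estimated change is a 3.3-fold lower number from compound 2 to compound 3 (0.52 log units; beyond the scatter). For compound 3 the expected value is 3000 nM, with an estimated range of 300 nM to 15000 nM.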

Compound 3, half-maximal inhibitory concentration: 700 nM
Estimate against measurement, compound 3: 4.3-fold (0.63 log units) above; low and high end bracket the measured number.
By their numbers in this assay, from the lowest: compound 3; then compounds 1 and 2 (each within the scatter of the next).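

In this assay, this position turns out to be able to shift the result, which the earlier swap between two directly attached aryl groups, within the scatter, gave no sign of. Putting (4-ethoxyphenyl)amino in place of 4-methoxy-3-methylphenyl gives a 14-fold lower number from compound 2 to compound 3 (1.15 log units; beyond the scatter) and putting it in place of 4-chlorophenyl gives a 7.4-fold lower number from compound 1 to compound 3 (0.87 log units; beyond the scatter), so compound 3 has the lowest number of the three, with both steps beyond the scatter. The change alters more than one feature at once, since the entering group brings a nitrogen and a hydrogen-bond donor as well as an ethoxy group, and nothing shown here separates their contributions or explains the drop.

The compounds shown leave open whether the amino link or the ethoxy group accounts for the shift: 4-ethoxyphenyl joined directly to the ring, or (4-methoxyphenyl)amino, would begin to pull the two apart. Also open, going by these compounds, is whether the amino hydrogen matters, a question that an N-methyl amino link at this place would address.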